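Isothiazolyl for trifluoromethoxyphenyl: cytotoxicity in HeLa cells

The compounds below may be only part of what the source reports. "The series", "measured", "known", "first", "only" and "open" are said of these compounds alone.

Compound 1, `COc1nc(-c2ccccc2F)ccc1[C@@H](c1ccccc1)[C@@](O)(CCN(C)C)c1cccc2ccccc12`: "nd" (no result reported) in a toxicity assay on HeLa cells (Homo sapiens) for cytotoxicity; a lower number here means that less compound is tolerated, a higher number that more compound is tolerated.
Compound 2, `COc1nc(-c2ccc(Br)cc2)ccc1[C@@H](c1ccccc1)[C@@](O)(CCN(C)C)c1cccc2ccccc12`: > 64 ug/mL.
Compound 3, `COc1nc(-c2ccc(OC(F)(F)F)cc2)ccc1[C@@H](c1ccccc1)[C@@](O)(CCN(C)C)c1cccc2ccccc12`: > 64 ug/mL.

The three compounds share one core and differ only in the group that sits on the aromatic carbon next to the ring nitrogen. Compound 1 carries a 2-fluorophenyl group there and has no result in this assay. Compound 2 carries a 4-bromophenyl group and gives > 64 ug/mL, which is a limit of this assay and not a number. Compound 3 carries a 4-(trifluoromethoxy)phenyl group and gives > 64 ug/mL, again a limit of this assay. Compound 3 thus stands at the upper edge of what this assay reports, alongside compound 2 (the limit of > 64 ug/mL in this assay, at which 2 of the 3 values shown sit). Among the compounds with values here, the single measured step, a step that the two limits leave unreadable from compound 2 to compound 3, cannot be read in size, so no measured step bears on the change ahead.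

Compound 4, `COc1nc(-c2cnsc2)ccc1[C@@H](c1ccccc1)[C@@](O)(CCN(C)C)c1cccc2ccccc12`, differs from compound 3 by 1,2-thiazol-4-yl in place of 4-(trifluoromethoxy)phenyl on an aromatic carbon. With both measured neighbours sitting at the limit, the step of a number no higher from compound 3 to compound 4 (the limit leaves the size open) is expected to lie within the scatter, with no direction favoured. For compound 4 the half-maximal cytotoxic concentration is therefore estimated at 64 ug/mL, within a range from 32 ug/mL to 128 ug/mL, most likely reported again as a limit only.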

Compound 4, half-maximal cytotoxic concentration: 28.8 ug/mL
The estimate for compound 4 lay 2.2-fold (0.35 log units) above the measured number; measured number outside the range, below it.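

The aromatic carbon next to the ring nitrogen turns out to be a place where a change can shift the result in this assay: 1,2-thiazol-4-yl in place of 4-(trifluoromethoxy)phenyl gives an at least 2.2-fold lower number from compound 3 to compound 4 (0.34 log units; beyond the scatter), and 1,2-thiazol-4-yl in place of 4-bromophenyl gives an at least 2.2-fold lower number from compound 2 to compound 4 (0.34 log units; beyond the scatter). From the compounds shown here alone, both steps lie beyond the scatter, but each starts from a limit of the assay rather than a number, so the full size of the drop stays unknown. Compound 4 therefore gives the first readable number at this place, whereas the step between the two substituted phenyl compounds cannot be read and both of them rest at the edge of the assay: the limit of > 64 ug/mL in this assay, at which 2 of the 4 values shown sit.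

The compounds shown leave open whether the lower number goes with the five-membered aromatic ring and its hetero atoms or simply with the loss of the substituted phenyl ring, a question that a thienyl, a pyridyl or an unsubstituted phenyl group here could help to separate. Also open, going by these compounds, is whether an amine or a carboxylic acid on the 1,2-thiazol-4-yl ring would shift the number again, and compound 1 gives "nd" (no result reported), so it adds nothing on this point.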